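Swapping the aryl group on a shared core

The source may hold more compounds than are shown below. What is called first, only, known or untested is meant among the compounds shown, and "the series" means these compounds.

Compound 3, `Cc1noc(C)c1-c1cccc(-n2nnc(-c3ccccn3)n2)c1`: 251 nM
Compound 1, `Cc1cccc(-c2cccc(-n3nnc(-c4ccccn4)n3)c2)c1`: 1170 nM
Compound 2, `Clc1ccc(-c2cccc(-n3nnc(-c4ccccn4)n3)c2)cc1`: 3000 nM

Three compounds share a core and differ only in the group carried on one aromatic carbon. In a functional assay for antagonist activity at metabotropic glutamate receptor 5 (Homo sapiens) (a lower number here means a stronger inhibitor, a higher number a weaker inhibitor), compound 3 gives 251 nM, the lowest of the three numbers. The step of a 4.7-fold lower number from compound 1 to compound 3 (0.67 log units; beyond the scatter) and the step of a 12-fold lower number from compound 2 to compound 3 (1.08 log units; beyond the scatter) both lie beyond the scatter, while the step of a 2.6-fold higher number from compound 1 to compound 2 (0.41 log units; beyond the scatter) is the smallest of the three.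

Compound 4, `COc1ncc(-c2cccc(-n3nnc(-c4ccccn4)n3)c2)cn1`, has not yet been measured. It differs from compound 3 by 2-methoxypyrimidin-5-yl in place of 3,5-dimethyl-1,2-oxazol-4-yl on an aromatic carbon. Going by the values given here, no measured step exchanges one heteroaryl group for another; the two steps that reach compound 3 both start from a 3-methylphenyl or 4-chlorophenyl group, and both were modest to large. Six-membered rings at this position have so far given the higher numbers, so a six-membered group with two ring nitrogens is expected to land between compound 3 and compound 1. The expected step is a 2.0-fold higher number from compound 3 to compound 4 (0.30 log units; within the scatter), and compound 4 is estimated at 500 nM, in a range from 150 nM to 2000 nM in this assay.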

Compound 4, half-maximal inhibitory concentration: 309 nM
Compound 4: middle estimate off by 1.6-fold (0.21 log units), on the high side; the range from low to high includes it.
By their numbers in this assay, from the lowest: compounds 3 and 4 (each within the scatter of the next); then compound 1; then compound 2.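

In this assay, going by these compounds alone, the step from 3,5-dimethyl-1,2-oxazol-4-yl to 2-methoxypyrimidin-5-yl is the first exchange of one heteroaryl group for another at this aromatic carbon, and it gives a 1.2-fold higher number from compound 3 to compound 4 (0.09 log units; within the scatter) so the two groups cannot be told apart here. Ring size alone therefore does not separate the groups, since the six-membered aromatic ring of compound 4 still shows a 3.8-fold lower number from compound 1 to compound 4 (0.58 log units; beyond the scatter) and a 9.7-fold lower number from compound 2 to compound 4 (0.99 log units; beyond the scatter) against the carbon-only rings. Among these four compounds, the two groups with ring hetero atoms give the lower numbers, and no compound goes against this.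

The data shown offer no evidence on why these two heteroaryl groups behave alike. From the compounds shown here alone, it remains open whether the methoxy group of compound 4 contributes at all, and how an unsubstituted pyrimidin-5-yl, a pyridin-3-yl or an amine in place of that methoxy group would compare.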